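Lengthening the ester chain from compound 3 to compound 4

This account rests on a few compounds, and the source may have more. Where it says the series, first, only, none or still open, it means among the compounds named here.

Values in a functional assay on COLO 320 cells (Homo sapiens) for cytotoxicity, read by MTT assay, with a stated time of 4 h; on this read-out lower numbers stand for stronger inhibition and higher numbers for weaker inhibition:
Compound 1 `COC(=O)C1=CO[C@@H](O[C@@H]2O[C@H](CO)[C@@H](OC(C)=O)[C@H](OC(C)=O)[C@H]2OC(C)=O)[C@@H]2[C@@H](C)[C@@H](OC(C)=O)C[C@H]12`: "not active" (no number reported)
Compound 2 `CCC(=O)OC[C@H]1O[C@@H](O[C@@H]2OC=C(C(=O)OC)[C@H]3C[C@H](OC(C)=O)[C@H](C)[C@@H]23)[C@H](OC(C)=O)[C@@H](OC(C)=O)[C@@H]1OC(C)=O`: 0.85 ug/mL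
Compound 3 `CCCCCCCCCCCC(=O)OC[C@H]1O[C@@H](O[C@@H]2OC=C(C(=O)OC)[C@H]3C[C@H](OC(C)=O)[C@H](C)[C@@H]23)[C@H](OC(C)=O)[C@@H](OC(C)=O)[C@@H]1OC(C)=O`: 0.04 ug/mL
Compound 4 `CCCCCCCCCCCCCC(=O)OC[C@H]1O[C@@H](O[C@@H]2OC=C(C(=O)OC)[C@H]3C[C@H](OC(C)=O)[C@H](C)[C@@H]23)[C@H](OC(C)=O)[C@@H](OC(C)=O)[C@@H]1OC(C)=O`: not yet measured

Compound 3 holds the lower of the two numbers in this assay, while compound 1 gives no number for comparison. The next change is ethyl in place of hydrogen on a saturated chain carbon, ten or more bonds along the chain from a carbonyl carbon, which is ethyl in place of hydrogen on a saturated chain carbon, ten or more bonds along the chain from a carbonyl carbon.

Among the measured compounds shown here, one measured step bears on this change: a 21-fold lower number from compound 2 to compound 3 (1.33 log units; beyond the scatter). That large step came with nonyl in place of hydrogen on a saturated chain carbon, two bonds along the chain from a carbonyl carbon. The new change is smaller and lies further out on the chain, and one step does not establish a trend. No shift beyond the scatter is therefore expected, though either direction remains possible.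

The expected change is no change at the digits printed from compound 3 to compound 4 (within the scatter) in this estimate. The estimated value for compound 4 is 0.04 ug/mL, with an expected range from 0.01 ug/mL to 0.2 ug/mL here.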

Compound 4, half-maximal inhibitory concentration: 30 ug/mL
The estimate for compound 4 lay 750-fold (2.88 log units) below the measured number, and the stated range ends below it.
By their numbers in this assay, from the lowest: compound 3; then compound 2; then compound 4.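

In this assay, the ester chain tolerates lengthening only up to a point: a 750-fold higher number from compound 3 to compound 4 (2.88 log units; beyond the scatter) comes with ethyl in place of hydrogen on a saturated chain carbon, ten or more bonds along the chain from a carbonyl carbon, and it runs opposite to a 21-fold lower number from compound 2 to compound 3 (1.33 log units; beyond the scatter) at the same ester. The longest chain also falls behind the shortest, with a 35-fold higher number from compound 2 to compound 4 (1.55 log units; beyond the scatter) as the net result of undecyl in place of hydrogen, so among these three esters the number does not follow chain length in one direction. Nothing measured here accounts for this reversal.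

Still open, going by these compounds, is how the number changes for chain lengths between those of compound 3 and compound 4, and whether a longer chain stays as weak as compound 4. Also open, on these data alone, is whether a chain of the length in compound 3 ending in an amine or a carboxylic acid keeps its low number.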